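Aryl amide in place of aryl ether at the same carbon

The source may hold more compounds than are shown below. What is called first, only, known or untested is meant among the compounds shown, and "the series" means these compounds.

Compound 3 `Nc1ncc(-c2cnn(C3CCNCC3)c2)cc1-c1nc2ccc(Oc3cc(Cl)ccn3)cc2o1` stands second highest of the three numbers in an assay on isolated protein for inhibition of G protein-coupled receptor kinase 5 (Homo sapiens), read by TR-FRET, with stated times of 10 min and 1 h (a higher number here means a weaker inhibitor, a lower number a stronger inhibitor), where compound 3 gives 5700 nM. Nearest is compound 2 `Nc1ncc(-c2cnn(C3CCNCC3)c2)cc1-c1nc2ccc(OCc3ccccc3)cc2o1`: in this assay compound 2 gives 6900 nM, and the step of a 1.2-fold lower number from compound 2 to compound 3 (0.08 log units; within the scatter) separates the two. Furthest is compound 1 `Nc1ncc(-c2cnn(C3CCNCC3)c2)cc1-c1nc2ccc(-c3cn[nH]c3)cc2o1`: in this assay compound 1 gives 1780 nM, and the steps of a 3.9-fold higher number from compound 1 to compound 2 (0.59 log units; beyond the scatter) and a 3.2-fold higher number from compound 1 to compound 3 (0.51 log units; beyond the scatter) both run toward weaker inhibition.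

Compound 4 `Nc1ncc(-c2cnn(C3CCNCC3)c2)cc1-c1nc2ccc(NC(=O)c3ccccc3)cc2o1` differs from compound 3 in one place: benzamido in place of (4-chloropyridin-2-yl)oxy on an aromatic carbon.

The measured steps bearing on this are the two from compound 1, which show that exchanging the pyrazolyl group for either larger aromatic group carrying an oxygen linker costs a modest amount, and the step of a 1.2-fold lower number from compound 2 to compound 3 (0.08 log units; within the scatter), which shows that the two oxygen-linked aromatic groups are interchangeable within the scatter. Going by the values given here, no measured step exchanges an oxygen linker for an amide, so the benzamido group itself is untested. Given that the change keeps a single six-membered aromatic ring on the same carbon, the expected step in this assay is none beyond the scatter, in no firm direction. Compound 4 is therefore expected to give 5000 nM in this assay, within a range of 1800 nM to 14000 nM, which corresponds to an expected step of a 1.1-fold lower number from compound 3 to compound 4 (0.06 log units; within the scatter).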

Compound 4, half-maximal inhibitory concentration: 3490 nM
Estimate against measurement, compound 4: 1.4-fold (0.16 log units) above, and the stated range covers the measured number.
By their numbers in this assay, from the lowest: compounds 1, 4, 3 and 2 (each within the scatter of the next, the first and the last beyond it).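

In this assay, the benzamido group on this aromatic carbon cannot be told apart from any of the three groups seen there before (a 1.6-fold lower number from compound 3 to compound 4 (0.21 log units; within the scatter)) (a 2.0-fold lower number from compound 2 to compound 4 (0.30 log units; within the scatter)) (a 2.0-fold higher number from compound 1 to compound 4 (0.29 log units; within the scatter)). The earlier compounds shown here showed only oxygen-linked aromatic groups, which stood beyond the scatter from the 1H-pyrazol-4-yl group of compound 1, whereas this amide-linked aromatic group, with its carbonyl and the amide hydrogen, stays within the scatter of that group and of both oxygen-linked groups, so the position accepts this linker without a change that can be read. No measurement in hand bears on what lies behind these steps.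

On these data alone, how a reversed amide, or an amide whose nitrogen carries a methyl group, would read on this carbon remains open, and so does the contribution of the amide hydrogen itself. Also open, as far as these compounds go, is whether a chloro or methoxy group on the benzamido ring, or a small amine or carboxylic acid in place of the whole group, would move the number beyond the scatter from compound 4.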